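The source may report more compounds than this note shows. Statements on the series, on what has been measured and on what is new or still open speak of the compounds shown alone.

Compound 1 `Cc1nc(C(=O)Nc2ccc(Cl)c(-c3nnc4c(Cl)cccn34)c2)cs1` in a functional assay on U-251 cells (Homo sapiens) for antiproliferative activity, read by MTT assay, with a stated time of 72 h (on this read-out higher numbers stand for weaker inhibition and lower numbers for stronger inhibition), gives 74300 nM.
Compound 2 `O=C(Nc1ccc(Cl)c(-c2nnc3c(Cl)cccn23)c1)c1c(F)cccc1Cl` in this assay gives > 100000 nM, which is a limit of the assay and not a number.
Compound 3 `O=C(Nc1ccc(Cl)c(-c2nnc3c(Cl)cccn23)c1)c1ccccc1Cl` in this assay gives > 100000 nM, again a limit of the assay and not a number.

Compound 3 therefore stands at the edge of what this assay can read, and the limit of > 100000 nM in this assay, at which 2 of the 3 values shown sit, shows that it shares that position with compound 2. Within the data shown here, the step of an at least 1.3-fold higher number from compound 1 to compound 3 (0.12 log units; that floor lies within the scatter), with 2-chlorophenyl in place of 2-methyl-1,3-thiazol-4-yl on a carbonyl carbon, and the step of an at least 1.3-fold higher number from compound 1 to compound 2 (0.12 log units; that floor lies within the scatter) both run from the one readable number toward the limit. The step that the two limits leave unreadable from compound 2 to compound 3 cannot be sized at all.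

Compound 4 `O=C(Nc1ccc(Cl)c(-c2nnc3c(Cl)cccn23)c1)c1ccon1` carries 1,2-oxazol-3-yl in place of 2-chlorophenyl on a carbonyl carbon. Among the measured compounds shown here, the steps that bear on it are the two from compound 1, and each of them only sets a floor that lies within the scatter. For the measured compounds named here, since compound 1, the one member with a five-membered heteroaryl ring on the carbonyl carbon, gave a readable number, compound 4 is expected to land near that number, with an at least 1.2-fold lower number from compound 3 to compound 4 (0.09 log units; that floor lies within the scatter) expected to be small and not reliably beyond the scatter. Compound 4 is estimated at 80000 nM, with a range from 30000 nM to 200000 nM.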

Compound 4, half-maximal inhibitory concentration: > 100000 nM
Compound 4 gave a limit, no number; the forecaster's own chance of this, stated with the estimate: 55%; middle value at least 1.2-fold (0.09 log units) away from the limit.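

Compound 4, with 1,2-oxazol-3-yl on the carbonyl carbon, gives a limit of the assay and not a number in this assay, so a five-membered aromatic ring in this place does not by itself ensure a readable value, and compound 1 goes against any simple split between these rings and the chlorinated phenyl groups, as it alone gives a number: the limit of > 100000 nM in this assay, at which 3 of the 4 values shown sit.

As far as these compounds go, the change from 2-methyl-1,3-thiazol-4-yl to 1,2-oxazol-3-yl gives an at least 1.3-fold higher number from compound 1 to compound 4 (0.12 log units; that floor lies within the scatter), so the data do not establish that the two rings differ, and the real size of this step remains unknown. The steps that join compound 4 to compound 2 and to compound 3 run between two limits and cannot be read.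

From the compounds shown here alone, how far compounds 2, 3 and 4 lie past the limit remains open, so no order among them can be given. Also open, going by these compounds, is whether an amine, a carboxylic acid or a longer chain on this carbonyl carbon, in place of these rings, would give a number clearly lower than that of compound 1.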